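Phenyl for pentyl on the ring amine of compound 2

This account rests on a few compounds, and the source may have more. Where it says the series, first, only, none or still open, it means among the compounds named here.

Measured compounds:
- compound 1, `CC(C)CCn1c(N2CCN(C)CC2)nc2ccccc21`, 1400 nM
- compound 2, `CCCCCN1CCN(c2nc3ccccc3n2CCOCC)CC1`, 30 nM
- compound 3, `CN1CCCN(c2nc3ccccc3n2CCOc2ccccc2)CC1`, 9.1 nM

Within a functional assay on ileum for inhibition of histamine H1 receptor (Cavia porcellus) (on this read-out higher numbers stand for weaker inhibition and lower numbers for stronger inhibition), compound 2 stands second highest of the three numbers. Its nearest neighbour is compound 3, whose number is lower by a gap beyond the scatter; compound 1 lies far above it, again beyond the scatter. Compound 4, `CCOCCn1c(N2CCN(c3ccccc3)CC2)nc2ccccc21`, has not been measured. It differs from compound 2 in one place: phenyl in place of pentyl on an amine nitrogen in a ring.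

For the measured compounds named here, no step between measured compounds covers this change, so the expectation rests on the shared core and the varied ring amine alone. A small step, if any, is expected from compound 2 to compound 4, not clearly beyond the scatter in either direction: a 1.3-fold higher number from compound 2 to compound 4 (0.12 log units; within the scatter). For compound 4 the estimate in this assay is 40 nM, with a range from 10 nM to 160 nM.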

Compound 4, half-maximal inhibitory concentration: > 10000 nM
Compound 4 was reported as a limit (the forecaster's own chance of this, stated with the estimate: 3%); at least 250-fold (2.39 log units) between middle value and limit.
By their numbers in this assay, from the lowest: compound 3; then compound 2; then compound 1. At a limit, above all of these: compound 4.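

Phenyl in place of pentyl on an amine nitrogen in a ring gives an at least 330-fold higher number from compound 2 to compound 4 (2.52 log units; beyond the scatter). In this assay compound 4 gives > 10000 nM, which is a limit and not a number. The earlier compounds shown here, none a one-place step from another, could not show that this nitrogen is so sensitive to the group it carries, even when both groups hold carbon only.

As far as these compounds go, whether the loss follows from the aromatic ring or from the loss of the open chain stays open. Cyclohexyl or benzyl on the same nitrogen would bear on this.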